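Half-Life After Exchanging the Group on the Carbonyl Carbon

This account rests on a few compounds, and the source may have more. Where it says the series, first, only, none or still open, it means among the compounds named here.

In an ADME assay on the whole organism (strain CD1) for metabolic stability, with Mus musculus as the target, read by LC-MS, at a dose of 5 mg/kg by the intravenous route (on this read-out lower numbers stand for a shorter-lived compound and higher numbers for a longer-lived compound), compound 1 (`Cc1c(Oc2cnc(C(=O)NCCO)cn2)ccc2c1B(O)OC2`) gives 3 h. Going by the values given here, compound 2 (`Cc1c(Oc2cnc(C(=O)N[C@@H](CO)CC(F)(F)F)cn2)ccc2c1B(O)OC2`) gives 3 h, which places it level with compound 1, its nearest measured neighbour and the only other compound with a number so far.

Compound 3 (`Cc1c(Oc2cnc(C(=O)N3CC(C)(O)C3)cn2)ccc2c1B(O)OC2`) has not yet been measured. It carries 3-hydroxy-3-methylazetidin-1-yl in place of (3,3,3-trifluoro-1-(hydroxymethyl)propyl)amino on a carbonyl carbon.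

Among the compounds with values here, the only measured step that bears on this exchange shows no change at the digits printed from compound 1 to compound 2 (within the scatter), with 2,2,2-trifluoroethyl in place of hydrogen on a saturated chain carbon, so no step beyond the scatter is expected in this assay. Within the data shown here, this support is thin, as that step stays within an open chain and no measured compound carries a ring on this carbonyl carbon. The range is therefore kept wide. The expected step is no change at the digits printed from compound 2 to compound 3 (within the scatter). For compound 3 the estimated half-life is 3 h, with an expected range from 1.5 h to 6 h.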

Compound 3, half-life: 7.1 h
Compound 3: middle estimate off by 2.4-fold (0.37 log units), on the low side; the whole stated range lies below it.
By their numbers in this assay, from the lowest: compounds 1 and 2 (each within the scatter of the next); then compound 3.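

In this assay, the group on the carbonyl carbon turned out to matter: the exchange gave a 2.4-fold higher number from compound 2 to compound 3 (0.37 log units; beyond the scatter) and, measured against the shorter open chain, a 2.4-fold higher number from compound 1 to compound 3 (0.37 log units; beyond the scatter) as well. The earlier pair had shown only no change at the digits printed from compound 1 to compound 2 (within the scatter) for a change within the open chain, so compound 3, the one compound here with a four-membered non-aromatic ring on this carbonyl carbon, is also the first to stand apart from the others in half-life. Nothing available here explains why the half-life of compound 3 is longer than those of compound 1 and compound 2.

With a single ring-bearing compound, the ring, the hydroxyl and the methyl group cannot be told apart as the source of the step, and an unsubstituted azetidin-1-yl or a 3-hydroxyazetidin-1-yl would be needed to separate them. Going by these compounds, whether the trend extends to larger rings also stays open, and a pyrrolidin-1-yl or a piperidin-1-yl group on the same carbonyl carbon would speak to that question.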